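A Methyl Group Added to a Compound at the Limit

The source may report more compounds than this note shows. Statements on the series, on what has been measured and on what is new or still open speak of the compounds shown alone.

Compound 1 `CC1=NN(C(=O)c2ccc(F)cc2)C(c2ccccc2O)C1`: 35400 nM
Compound 2 `CC1=NN(C(=O)CCl)C(c2cc(F)ccc2O)C1`: 6870 nM
Compound 3 `CC1=NN(S(=O)(=O)c2ccccc2)C(c2cc(Br)ccc2O)C1`: > 60000 nM (a limit of the assay, not a number)

All three values come from a functional assay on MGC-803 cells (Homo sapiens) for antiproliferative activity, read by MTT assay, with a stated time of 48 h; a higher number here means that more compound is needed for the effect, a lower number that less compound is needed. In this assay compound 3 gives > 60000 nM, which is a limit and not a measured number. The three values include just this one case: the limit of > 60000 nM in this assay, at which 1 of the 3 values shown sits. Compound 1 and compound 2 do have numbers, but each differs from compound 3 in more than one place, so neither isolates a single change.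

Compound 4 `CC1=NN(S(=O)(=O)c2ccccc2C)C(c2cc(Br)ccc2O)C1` differs from compound 3 in one place only, with methyl in place of hydrogen on an aromatic carbon, so that phenyl becomes 2-methylphenyl (methyl in place of hydrogen on an aromatic carbon). Among the measured compounds shown here, no measured pair here shows what this change does, and compound 3 offers no exact number as a starting point. Only a small shift is therefore expected in this assay, in the direction of slightly less compound being needed. The expected step is an at least 1.2-fold lower number from compound 3 to compound 4 (0.07 log units; that floor lies within the scatter). A result reported only as a limit would also be unsurprising. For compound 4 the estimated value is 50000 nM, with an expected range from 18000 nM to 110000 nM.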

Compound 4, half-maximal effective concentration: > 60000 nM
Compound 4 gave a limit, no number; the forecaster's own chance of this, stated with the estimate: 55%; middle value at least 1.2-fold (0.07 log units) from the limit.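

In this assay compound 4 gives > 60000 nM, a limit and not a number. As far as these compounds go, compound 3 stands at the same limit, so no step can be read between compound 3 and compound 4: the limit of > 60000 nM in this assay, at which 2 of the 4 values shown sit. Whether methyl in place of hydrogen on an aromatic carbon changes the amount of compound needed, in either direction, stays open.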